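From formyl to hydroxymethyl in compound 1

This account rests on a few compounds, and the source may have more. Where it says the series, first, only, none or still open, it means among the compounds named here.

In an ADME assay on BAEC cells (Bos taurus) for cytotoxicity, read by MTT assay, with a stated time of 2 days (a higher number here means a weaker inhibitor, a lower number a stronger inhibitor), compound 1 `COc1c(Br)cc(C=O)c(OCc2ccccc2)c1Br` gives > 12500 nM, which is a limit and not a number.

Two relatives do give numbers: compound 2 `COC(=O)COc1c(C=O)cc(Br)c(OC)c1Br` gives 151000 nM, and compound 3 `COc1c(Br)cc(C=O)c(OC(C)=O)c1Br` gives 23000 nM. The step that the limit leaves unreadable from compound 1 to compound 2 cannot be sized, while a 6.6-fold lower number from compound 2 to compound 3 (0.82 log units; beyond the scatter) is modest. Both steps alter the group on an oxygen on an aromatic ring and keep the formyl.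

Compound 4 `COc1c(Br)cc(CO)c(OCc2ccccc2)c1Br` alters the formyl itself: hydroxymethyl in place of formyl on an aromatic carbon. For the measured compounds named here, no measured step covers this change, so the modest size of a 6.6-fold lower number from compound 2 to compound 3 (0.82 log units; beyond the scatter) serves only as a rough guide, and a small shift is expected in this assay. The estimated change is a step that the limit leaves unreadable from compound 1 to compound 4. Compound 4 is expected at 25000 nM, with an estimated range of 10000 nM to 90000 nM.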

Compound 4, half-maximal inhibitory concentration: > 12000 nM
Compound 4 gave a limit, no number; the forecaster's own chance of this, stated with the estimate: 45%; the middle value is on the limit's open side.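

In this assay compound 1 gives > 12500 nM, which is a limit. For the compounds shown here, compound 4 also gives only a limit, > 12000 nM, and no step between compound 1 and compound 4 can be read. Going by these compounds, whether hydroxymethyl in place of formyl changes the result at all stays open.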